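Swapping the aryl group on the cinnamoyl-type chain

The source may report more compounds than this note shows. Statements on the series, on what has been measured and on what is new or still open speak of the compounds shown alone.

Measured so far:
- compound 1, `COC1=C(C)C(=O)/C(=C(O)/C=C/c2ccc(Br)cc2)C(=O)C1(C)C`: 9 ug/mL
- compound 2, `COC1=C(C)C(=O)/C(=C(O)/C=C/c2ccc(OC)cc2)C(=O)C1(C)C`: 9.2 ug/mL
- compound 3, `COC1=C(C)C(=O)/C(=C(O)/C=C/c2ccc(O)cc2)C(=O)C1(C)C`: 14.9 ug/mL

These three compounds share one core and differ only in the group on the aromatic ring at the end of the chain. In a functional assay on A-431 cells (Homo sapiens) for cytotoxicity (a higher number here means that more compound is needed for the effect, a lower number that less compound is needed), compound 2 gives 9.2 ug/mL. Its nearest neighbour is compound 1, and the step of a 1.0-fold higher number from compound 1 to compound 2 (0.01 log units; within the scatter) lies within the scatter. Compound 3 is furthest off, with a 1.6-fold higher number from compound 2 to compound 3 (0.21 log units; within the scatter) also within the scatter, as is a 1.7-fold higher number from compound 1 to compound 3 (0.22 log units; within the scatter). So across the three measured compounds the changes on that ring have not moved the number beyond the noise.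

Compound 4, `COC1=C(C)C(=O)/C(=C(O)/C=C/c2c(C)cccc2C)C(=O)C1(C)C`, is not yet measured. The change from compound 2 is 2,6-dimethylphenyl in place of 4-methoxyphenyl on a double-bonded chain carbon bound to a double-bonded chain carbon. Going by the values given here, none of the measured steps swaps the whole aromatic group or puts two methyl groups on it, so there is no direct precedent. Among the compounds with values here, the only evidence is that three different substituents on that ring left this assay unchanged within the scatter, which suggests a step of a 1.1-fold higher number from compound 2 to compound 4 (0.04 log units; within the scatter) near zero is expected, with wider uncertainty because the change is larger than any measured one. Compound 4 is therefore estimated at 10 ug/mL, within 4 ug/mL to 25 ug/mL.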

Compound 4, concentration for half-maximal effect: 10.1 ug/mL
The estimate for compound 4 lay 1.0-fold (0.00 log units) below the measured number; the range from low to high includes it.
By their numbers in this assay, from the lowest: compounds 1, 2, 4 and 3 (each within the scatter of the next).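

Exchanging the whole aromatic group, rather than a single substituent on it, still does not move the number in this assay beyond the scatter: the result is a 1.1-fold higher number from compound 2 to compound 4 (0.04 log units; within the scatter) and a 1.1-fold higher number from compound 1 to compound 4 (0.05 log units; within the scatter) and also a 1.5-fold lower number from compound 3 to compound 4 (0.17 log units; within the scatter) in this series. At this position, on a double-bonded chain carbon bound to a double-bonded chain carbon, 2,6-dimethylphenyl therefore sits alongside 4-bromophenyl, 4-methoxyphenyl and 4-hydroxyphenyl with no measurable separation, and the new group carries two methyl groups and no oxygen at all. Nothing available explains why these four compounds stay so close together.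

As far as these compounds go, all four compounds keep a carbon-only aromatic ring at the end of the chain, so it remains open whether a ring carrying an amine or a carboxylic acid, a nitrogen-containing aromatic ring, or a saturated cyclohexyl ring would separate from them. From the compounds shown here alone, whether the number responds to any change at all also remains open for the shared core, such as exchanging its methoxy group or shortening or lengthening the chain that joins the core to the ring.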